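Removing a Methyl from an Aromatic Oxygen: An Expectation

The compounds below may be only part of what the source reports. "The series", "measured", "known", "first", "only" and "open" are said of these compounds alone.

Compound 1, `O=C(Nc1cccc(-n2cc(-c3ccncc3)c(-c3ccc(Cl)c(O)c3)n2)c1)Nc1cccc(C(F)(F)F)c1`, in a functional assay on PC-3 cells (Homo sapiens) for inhibition, read by sulforhodamine B assay, with a stated time of 48 h (a lower number here means a stronger inhibitor of growth, a higher number a weaker inhibitor of growth), gives 948 nM.
Compound 2, `COc1cc(-c2nn(-c3cccc(NC(=O)c4cccc(C(F)(F)F)c4)c3)cc2-c2ccncc2)ccc1Cl`, gives 1230 nM.
Compound 3, `COc1cc(-c2nn(-c3cccc(NC(=O)Nc4ccc(Cl)c(Cl)c4)c3)cc2-c2ccncc2)ccc1Cl`, gives 554 nM.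

Compound 3 stands at the low end of these three numbers. Its gap to compound 1 lies within the scatter, so the two cannot be set in order; the step of a 2.2-fold lower number from compound 2 to compound 3 (0.35 log units; beyond the scatter) is beyond the scatter. Compound 4, `O=C(Nc1cccc(-n2cc(-c3ccncc3)c(-c3ccc(Cl)c(O)c3)n2)c1)Nc1ccc(Cl)c(Cl)c1`, is made from compound 3 by hydrogen in place of methyl on an oxygen on an aromatic ring. Within the data shown here, no measured pair differs only at this oxygen, so no measured step bears on this change directly. Compound 1 and compound 3 differ both at this oxygen and in the group on the carbonyl carbon, and their numbers lie within the scatter of each other, which gives no sign that the oxygen change matters much in this assay. I therefore expect a step of a 1.0-fold lower number from compound 3 to compound 4 (0.00 log units; within the scatter) that stays within the scatter. Compound 4 is estimated at 550 nM, with a range from 200 nM to 1500 nM.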

Compound 4, concentration for 50% growth inhibition: 834 nM
Compound 4: the middle estimate sits 1.5-fold (0.18 log units) below what was measured, within the range that was stated.
By their numbers in this assay, from the lowest: compounds 3, 4, 1 and 2 (each within the scatter of the next, the first and the last beyond it).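

Among these compounds, the pair compound 3 and compound 4 is the first here that differs only at this oxygen, and in this assay replacing methoxy with hydroxy gives a 1.5-fold higher number from compound 3 to compound 4 (0.18 log units; within the scatter) so this single change cannot be told apart from no change. With the hydroxy held constant, changing the group on the amide-type nitrogen gives a 1.1-fold lower number from compound 1 to compound 4 (0.06 log units; within the scatter) so 3,4-dichlorophenyl and 3-(trifluoromethyl)phenyl cannot be set in order on this hydroxy background either. Nothing shown here speaks to why these numbers lie so close.

At this position the compounds shown cover only methoxy and hydroxy. On these data alone, whether a longer chain on the oxygen, such as ethoxy, or an amine in place of the hydroxy would stay within the same range remains open.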